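Boronic ester removal on a furoxan sulfone series

A few compounds are considered here, and "the series" means these few. Any claim that something is new, unique, unknown or untested is made for them only; others in the source may bear on it.

Compounds measured in a functional assay on PANC-1 cells (Homo sapiens) for cytotoxicity, read by MTT assay, with a stated time of 48 h; on this read-out lower numbers stand for stronger inhibition and higher numbers for weaker inhibition:
compound 1 `O=C(c1ccc2cccc(OCc3ccc(B(O)O)cc3)c2n1)N1CCC(Oc2no[n+]([O-])c2S(=O)(=O)c2ccccc2)CC1` gives 16600 nM
compound 2 `O=C(c1ccc2cccc(O)c2n1)N1CCC(Oc2no[n+]([O-])c2S(=O)(=O)c2ccccc2)CC1` gives 9050 nM
compound 3 `O=C(NCCCOc1no[n+]([O-])c1S(=O)(=O)c1ccccc1)c1ccc2cccc(OCc3ccc(B(O)O)cc3)c2n1` gives 10500 nM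

The three measured compounds share a furoxan sulfone fragment and a bicyclic aromatic amide, and they differ in two ways. Compound 1 and compound 2 carry a piperidine linker, while compound 3 carries an open chain linker; the difference between the two cores is not broken down here. The second difference is the group on the aromatic oxygen: compound 1 and compound 3 carry a boronic acid bearing benzyl group, whereas compound 2 carries only a hydrogen there. The change from compound 1 to compound 2 is a hydrogen atom in place of a group of 10 heavy atoms (7 carbon, 1 boron, 2 oxygen; one six-membered aromatic ring of carbon only), on an oxygen on an aromatic ring, and in this assay it gave a 1.8-fold lower number from compound 1 to compound 2 (0.26 log units; within the scatter).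

Compound 4 `O=C(NCCCOc1no[n+]([O-])c1S(=O)(=O)c1ccccc1)c1ccc2cccc(O)c2n1` is the untested partner of compound 3. It differs from compound 3 by a hydrogen atom in place of a group of 10 heavy atoms (7 carbon, 1 boron, 2 oxygen; one six-membered aromatic ring of carbon only), on an oxygen on an aromatic ring, the same kind of change as that from compound 1 to compound 2, at a place described in the same words. The values of compound 2 and compound 3 are within the scatter of one another, so the series gives no sign that the linker matters much here.

For the measured compounds named here, compound 4 is expected to show a step of about a 1.6-fold lower number from compound 3 to compound 4 (0.21 log units; within the scatter), resting on the single earlier step of a 1.8-fold lower number from compound 1 to compound 2 (0.26 log units; within the scatter), which itself lay within the scatter. Compound 4 is therefore estimated at 6500 nM, with a range from 3000 nM to 14000 nM.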

Compound 4, half-maximal inhibitory concentration: 7540 nM
Compound 4: the middle estimate sits 1.2-fold (0.06 log units) below what was measured, and the stated range covers the measured number.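

In this assay, a hydrogen atom in place of the group of 10 heavy atoms, on an oxygen on an aromatic ring, gave a 1.4-fold lower number from compound 3 to compound 4 (0.14 log units; within the scatter) on the open chain core. Set beside the same change on the piperidine core, the two steps agree: the same change on two cores in this assay, a 1.8-fold lower number (0.26 log units; within the scatter) from compound 1 to compound 2 and a 1.4-fold lower number (0.14 log units; within the scatter) from compound 3 to compound 4, 1.3-fold (0.12 log units) apart, within the scatter of two such steps. This shows that, across these two cores, the change behaves alike and stays too small to be told apart from the usual scatter, but it does not show that the boronic acid bearing benzyl group has any real effect on the read-out, nor that the agreement would hold on a core outside these two pairs.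

The compounds shown leave open whether a different group on that oxygen, such as a methyl group, a plain benzyl group without boron, or a benzyl group carrying an amine or a carboxylic acid in place of the boronic acid, would give a step that stands clear of the scatter. They also leave open whether a longer chain in the open chain linker, or a replacement of the phenyl ring on the sulfone, would move the numbers in this cell line.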